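The source may report more compounds than this note shows. Statements on the series, on what has been measured and on what is new or still open speak of the compounds shown alone.

Measured compounds:
Compound 1 `NC1=NC2(CCOCC2)N(OCCCOc2ccccc2)C(N)=N1` gives > 90%, a limit of the assay.
Compound 2 `NC1=NC2(CCOCC2)N(OCCCOc2ccc(Cl)cc2Cl)C(N)=N1` gives > 90%, also a limit.
Compound 3 `NC1=NC2(CCOCC2)N(OCCCOc2cc(Cl)c(Cl)cc2Cl)C(N)=N1` gives > 90%, again a limit.

All three values above come from an assay on isolated protein for inhibition of Dihydrofolate reductase (Homo sapiens), read by spectrophotometry, using NADPH, with stated times of 5 s and 6 min, tested at 5 uM; a higher number here means a stronger effect of the compound at the concentration tested, a lower number a weaker effect. Compound 3 thus stands at the limit, with no number of its own; the steps a step that the two limits leave unreadable from compound 1 to compound 2, a step that the two limits leave unreadable from compound 1 to compound 3 and a step that the two limits leave unreadable from compound 2 to compound 3 give no size because every value sits at the limit of > 90% in this assay, at which 3 of the 3 values shown sit. Compound 4 `NC1=NC2(CCOCC2)N(OCCCOc2cccc(Br)c2)C(N)=N1` differs from compound 3 by 3-bromophenyl in place of 2,4,5-trichlorophenyl on an oxygen on a saturated carbon. The three measured steps bear on this change in that they also swap the aryl group on the same oxygen, yet none gives a readable size. A step of a number no higher from compound 3 to compound 4 (the limit leaves the size open) is therefore expected, within the scatter. Compound 4 is estimated at 90%, between 75% and 98%.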

Compound 4, a percentage reported as inhibition, at one concentration (the size of the read-out at that concentration, not a potency): 86.7%
For compound 4 the middle estimate is 3.3 percentage points above the measured one; the measured number falls inside the stated range.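

In this assay, going by these compounds alone, compound 4 gives 86.7%, the first value that is a number rather than a limit, so a single 3-bromophenyl on this oxygen still leaves a high read-out. The steps are a number at least 3.3 percentage points lower from compound 3 to compound 4 (that floor lies within the scatter), a number at least 3.3 percentage points lower from compound 2 to compound 4 (that floor lies within the scatter) and a number at least 3.3 percentage points lower from compound 1 to compound 4 (that floor lies within the scatter), so no drop beyond the scatter can be claimed. Their true sizes stay open, and the steps among the other three compounds cannot be read: the limit of > 90% in this assay, at which 3 of the 4 values shown sit.

Going by these compounds, whether an aryl group carrying an amine or a carboxylic acid would hold the read-out remains open. So does the effect of a longer chain between this oxygen and the aryl ring.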